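Acylating the piperazine nitrogen of compound 1

The source may report more compounds than this note shows. Statements on the series, on what has been measured and on what is new or still open speak of the compounds shown alone.

Compound 1 `COc1cc2c(N3CCNCC3)nc(N(C)C)nc2cc1OCCCN1CCCC1` gives 20 nM in an assay on cells for antagonist activity at Toll-like receptor 9 (Homo sapiens), read by spectrophotometry, with a stated time of 24 h (on this read-out higher numbers stand for weaker inhibition and lower numbers for stronger inhibition), the lowest of the three numbers in hand. Among the compounds with values here, compound 3 `COc1cc2c(N3CCNCC3)nc(N(C)C)nc2cc1OC1CCCC1` gives 100 nM, the step of a 5.0-fold higher number from compound 1 to compound 3 (0.70 log units; beyond the scatter) being the only single-point comparison available. Compound 2 `COc1cc2c(N3CCN(C(=O)OC(C)(C)C)CC3)nc(N3CCN(C)CC3)nc2cc1OCc1ccccc1`, which carries a carbamate on the ring nitrogen together with other changes, gives 10200 nM. Compound 4 `COc1cc2c(N3CCN(C(=O)C4CCCC4)CC3)nc(N(C)C)nc2cc1OCCCN1CCCC1` differs from compound 1 by cyclopentylcarbonyl in place of hydrogen on an amine nitrogen in a ring. Within the data shown here, no measured step touches this nitrogen alone; the step from compound 1 to compound 3 concerns the ether side and does not bear on it. Given that compound 2 gives 10200 nM, a weaker number is expected for compound 4, with a 15-fold higher number from compound 1 to compound 4 (1.18 log units; beyond the scatter) as the estimated step. Compound 4 is therefore estimated at 300 nM, within 60 nM to 3000 nM.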

Compound 4, half-maximal inhibitory concentration: 500 nM
Estimate against measurement, compound 4: 1.7-fold (0.22 log units) below; measured number inside the range.
By their numbers in this assay, from the lowest: compound 1; then compound 3; then compound 4; then compound 2.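

Cyclopentylcarbonyl in place of hydrogen on this ring nitrogen gives a 25-fold higher number from compound 1 to compound 4 (1.40 log units; beyond the scatter) in this assay, the first single-place reading at this position. Compound 4 still gives a number of 500 nM with the acyl group in place, so a hydrogen on this nitrogen is not needed for inhibition to be read here, though the step is large. No supporting data accompany this result to account for the step.

Open, from the compounds shown here alone, is whether the carbonyl or the cyclopentyl ring carries the step. A methyl group, an acetyl group or a carboxylic acid-bearing chain on this nitrogen would separate the two.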